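Low-toxicity variants of a shared core: a pyridinylmethyl replacement

The source may report more compounds than this note shows. Statements on the series, on what has been measured and on what is new or still open speak of the compounds shown alone.

Compound 1, `CC(C)CCn1nc(-c2ccn(C)c2)c(O)c(C2=NS(=O)(=O)c3cc(NS(C)(=O)=O)ccc3N2)c1=O` — in an ADME assay on Huh-7 cells (Homo sapiens) for cytotoxicity, with a stated time of 72 h (on this read-out higher numbers stand for lower toxicity in this test and lower numbers for higher toxicity in this test), compound 1 gives > 1000 nM, which is a limit of the assay and not a number.
Compound 2, `CCC(C)n1nc(-c2cccs2)c(O)c(C2=NS(=O)(=O)c3cc(NS(C)(=O)=O)ccc3N2)c1=O` — in this assay compound 2 gives > 33000 nM, which is likewise a limit of the assay.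

Within the data shown here, compound 2 therefore stands only at a limit in this assay; the one further value shown, for compound 1, is also a limit, so no measured step between the two can be counted. The evidence consists of the limit of > 1000 nM in this assay, at which 1 of the 2 values shown sits, and of the limit of > 33000 nM in this assay, at which 1 of the 2 values shown sits, nothing more.

Compound 3, `CS(=O)(=O)Nc1ccc2c(c1)S(=O)(=O)N=C(c1c(O)c(-c3cccs3)nn(Cc3ccccn3)c1=O)N2`, has not yet been measured in this assay. It differs from compound 2 in one place: (pyridin-2-yl)methyl in place of sec-butyl on an aromatic nitrogen. The rest of the shared core is kept unchanged.

Among the measured compounds shown here, with no measured step on record, the expectation rests on the two limits alone. Compound 3 is expected to remain weakly cytotoxic, and the step of an at least 1.1-fold lower number from compound 2 to compound 3 (0.04 log units; that floor lies within the scatter) is expected to be none beyond the usual scatter, in no particular direction. For compound 3 the estimated value in this assay is 30000 nM, with a range from 8000 nM to 100000 nM.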

Compound 3, half-maximal cytotoxic concentration: > 1000 nM
Compound 3 ended at the assay's limit; the forecaster's own chance of this, stated with the estimate: 70%; the middle value lies beyond the limit too.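

In this assay compound 3 gives > 1000 nM as a limit of the assay and not a number. Among these compounds, compound 2 gives > 33000 nM as a limit too, so no step from compound 2 to compound 3 can be read. The compounds shown leave open whether (pyridin-2-yl)methyl in place of sec-butyl changes the result in this assay at all.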